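The source may report more compounds than this note shows. Statements on the series, on what has been measured and on what is new or still open speak of the compounds shown alone.

Measured in a functional assay on HCT-116 cells (Homo sapiens) for antiproliferative activity, read by WST assay, with a stated time of 72 h; a lower number here means a stronger inhibitor of growth, a higher number a weaker inhibitor of growth:

- compound 1 `O=C(NO)c1cnc(N2C[C@@H]3[C@H](C2)[C@H]3NC(=O)c2ccc3ccccc3c2)nc1` gives 410 nM
- compound 2 `O=C(NO)c1cnc(N2C[C@@H]3[C@H](C2)[C@H]3NC(=O)c2cccs2)nc1` gives 3600 nM
- compound 3 `O=C(NO)c1cnc(N2C[C@@H]3[C@H](C2)[C@H]3NC(=O)c2ccccc2)nc1` gives 5100 nM

Compound 3 at 5100 nM and compound 2 at 3600 nM share the high end of these numbers, and compound 1 at 410 nM lies well below both.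

Next comes compound 4 `O=C(NO)c1cnc(N2C[C@@H]3[C@H](C2)[C@H]3NCc2ccc(F)cc2)nc1`, which has 4-fluorobenzyl in place of benzoyl on an amine nitrogen.

For the measured compounds named here, the only measured step is a 1.4-fold higher number from compound 2 to compound 3 (0.15 log units; within the scatter), which has phenyl in place of thiophen-2-yl on a carbonyl carbon. It stays within the scatter and keeps the carbonyl, so it bears only weakly on this change. Going by the values given here, no measured step removes the carbonyl. Among the compounds with values here, compound 1 at 410 nM shows only that the number can lie well below that of compound 3 with the carbonyl kept.

A move to a lower number in this assay is expected, though with little direct support. The estimated step is a 5.7-fold lower number from compound 3 to compound 4 (0.75 log units; beyond the scatter). For compound 4 the estimate is 900 nM, with an expected range of 200 nM to 4000 nM.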

Compound 4, concentration for 50% growth inhibition: 380 nM
Compound 4: the middle estimate sits 2.4-fold (0.37 log units) above what was measured; the measured number falls inside the stated range.
By their numbers in this assay, from the lowest: compounds 4 and 1 (each within the scatter of the next); then compounds 2 and 3 (each within the scatter of the next).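

In this assay, placing 4-fluorobenzyl in place of benzoyl on the amine nitrogen gives a 13-fold lower number from compound 3 to compound 4 (1.13 log units; beyond the scatter), and placing it in place of (thiophen-2-yl)carbonyl gives a 9.5-fold lower number from compound 2 to compound 4 (0.98 log units; beyond the scatter). For the compounds shown here, these are the first steps that remove the carbonyl, and they show that a number as low as that of compound 1 at 410 nM does not depend on keeping the carbonyl at this position: compound 4 at 380 nM lies within the scatter of it, with a single aromatic ring of carbon only in the entering group. No measured evidence accounts for the size of these steps.

The change removes the carbonyl and brings in fluorine together, so the two contributions cannot be separated from these compounds. A plain benzyl group on the same nitrogen would separate them, and a naphthalen-2-ylmethyl group would show whether the larger ring system of compound 1 adds anything once the carbonyl is gone.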